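Removing a Methyl from an Aromatic Oxygen

This account rests on a few compounds, and the source may have more. Where it says the series, first, only, none or still open, it means among the compounds named here.

Two measured compounds share one core. Compound 2 `COc1cc(C)cc(-c2nn(CC#N)cc2-c2ccnc(-c3ccc(N(C)C)cc3)c2)c1` and compound 1 `Cc1cc(O)cc(-c2nn(CC#N)cc2-c2ccnc(-c3ccc(Oc4ccccc4)cc3)c2)c1` differ in more than one place, so only their values can be set side by side. In a functional assay on HCC 2998 cells (Homo sapiens) for inhibition, read by sulforhodamine B assay, with a stated time of 48 h (a lower number here means a stronger inhibitor of growth, a higher number a weaker inhibitor of growth), compound 2 gives 1930 nM, the smaller of the two values shown, though the gap to compound 1 lies within the scatter. Compound 1 gives 3390 nM. Compound 3 `Cc1cc(O)cc(-c2nn(CC#N)cc2-c2ccnc(-c3ccc(N(C)C)cc3)c2)c1` has not been measured; it differs from compound 2 by hydrogen in place of methyl on an oxygen on an aromatic ring. Going by the values given here, no measured step of this kind exists here, so the expected change from compound 2 to compound 3, a 1.0-fold higher number from compound 2 to compound 3 (0.02 log units; within the scatter), is small and of uncertain direction, not beyond the scatter. Compound 3 is therefore estimated at 2000 nM, within 700 nM to 6000 nM.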

Compound 3, concentration for total growth inhibition: 13200 nM
Compound 3: the middle estimate sits 6.6-fold (0.82 log units) below what was measured; measured number above the stated range.
By their numbers in this assay, from the lowest: compounds 2 and 1 (each within the scatter of the next); then compound 3.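

In this assay the change from methoxy to hydroxy gives a 6.8-fold higher number from compound 2 to compound 3 (0.84 log units; beyond the scatter) and so this position is not indifferent to losing the methyl. With hydroxy kept in place, dimethylamino in place of phenoxy on an aromatic carbon gives a 3.9-fold higher number from compound 1 to compound 3 (0.59 log units; beyond the scatter) which shows that the group at that other place also counts. Nothing available here offers a reason for either step.

From the compounds shown here alone, whether ethoxy or an amine on this ring would match methoxy remains open. So does whether methoxy would give the same gain alongside phenoxy.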